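A few compounds are considered here, and "the series" means these few. Any claim that something is new, unique, unknown or untested is made for them only; others in the source may bear on it.

Compound 1 `CCCCCOC(=O)N1CCN(C(=O)[C@H](CCC(=O)O)NC(=O)c2nc(-c3ccccc3)cc(N3CCC(COC)CC3)n2)CC1`: in an in vivo ADME assay on the whole organism (strain Sprague-Dawley) for pharmacokinetics, with Rattus norvegicus as the target (on this read-out lower numbers stand for slow clearance and higher numbers for fast clearance), compound 1 gives 6 mL/min/kg
Compound 2 `CCCCCOC(=O)N1CCN(C(=O)[C@H](CCC(=O)O)NC(=O)c2cc(N3CCC(OCCO)CC3)nc(-c3ccccc3)n2)CC1`: compound 2 gives 18 mL/min/kg
Compound 3 `CCCCCOC(=O)N1CCN(C(=O)[C@H](CCC(=O)O)NC(=O)c2cc(N3CCC(C(=O)NCC)CC3)nc(-c3ccccc3)n2)CC1`: compound 3 gives 8 mL/min/kg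

Among the three measured numbers compound 1 stands lowest. Its gap to compound 3 lies within the scatter of repeated measurements, so the two cannot be told apart, whereas its gap to compound 2 lies beyond the scatter. Going by the values given here, the one step that can be read within the set is a 2.3-fold lower number from compound 2 to compound 3 (0.35 log units; beyond the scatter), a change on a saturated ring carbon of the shared core's saturated ring.

Compound 4 `CCCCCOC(=O)N1CCN(C(=O)[C@H](CCC(=O)O)NC(=O)c2nc(-c3ccccc3)cc(N3CCC(CN)CC3)n2)CC1` is the next step from compound 1: amino in place of methoxy on a saturated chain carbon bound to a saturated ring carbon. Among the compounds with values here, no measured step exchanges these two groups, and the step from compound 2 to compound 3 concerns different groups at a different place, so it bears on compound 4 only by showing that a change on that ring region can move this assay modestly. The expected step is therefore small: compound 4 is expected to differ from compound 1 by a 1.3-fold higher number from compound 1 to compound 4 (0.12 log units; within the scatter), which stays within the scatter. Compound 4 is estimated at 8 mL/min/kg, within a range from 4 mL/min/kg to 16 mL/min/kg.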

Compound 4, clearance: 16 mL/min/kg
The estimate for compound 4 lay 2.0-fold (0.30 log units) below the measured number, and the stated range covers the measured number.
By their numbers in this assay, from the lowest: compounds 1, 3, 4 and 2 (each within the scatter of the next, the first and the last beyond it).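

In this assay the exchange of methoxy for amino on a saturated chain carbon bound to a saturated ring carbon gives a 2.7-fold higher number from compound 1 to compound 4 (0.43 log units; beyond the scatter) and so moves clearance beyond the scatter. Going by these compounds alone, until now the only readable step was a 2.3-fold lower number from compound 2 to compound 3 (0.35 log units; beyond the scatter) on a saturated ring carbon, and the new step shows that a change on the chain carbon, from methoxymethyl to aminomethyl, can also move this read-out by a modest step. No measurement in hand explains this step.

From the compounds shown here alone, it remains open whether the step belongs to the amino group itself or would follow from other replacements of methoxy, a question that a hydroxyl, a dimethylamino group or a carboxylic acid on the same chain carbon would help settle, while a longer chain ending in an amine would test whether the length of the chain matters. A single exchange on the shared core also cannot show whether amino in place of methoxy would give a similar step on a different core.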